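From isobutyl to chloro: one swap, little to go on

A few compounds are considered here, and "the series" means these few. Any claim that something is new, unique, unknown or untested is made for them only; others in the source may bear on it.

compound 1 `CC(C)Cc1ccc(C(=O)/C=C/c2ccc(C(=O)O)cc2)cc1` gives < 10 ug/mL (a limit)
compound 2 `COC(=O)c1cc(-c2cccc(NC(=O)c3ccc(/C=C/C(=O)c4cccc(C(F)(F)F)c4)cc3)c2)on1` gives > 20 ug/mL (a limit)
compound 3 `COC(=O)c1cc(-c2cccc(NC(=O)c3ccc(/C=C/C(=O)c4cccc(Br)c4)cc3)c2)on1` gives > 100 ug/mL (a limit)

In an ADME assay on Vero cells (Chlorocebus sabaeus) for cytotoxicity, read by MTT assay, with a stated time of 72 h (on this read-out higher numbers stand for lower toxicity in this test and lower numbers for higher toxicity in this test), compound 1 gives < 10 ug/mL, which is a limit and not a number. Compound 2 and compound 3 also have only limits, so none of the three has an exact value to start from.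

Compound 4 `O=C(O)c1ccc(/C=C/C(=O)c2ccc(Cl)cc2)cc1` differs from compound 1 in one place: chloro in place of isobutyl on an aromatic carbon.

One measured step also swaps one group for another on an aromatic carbon: a step that the two limits leave unreadable from compound 2 to compound 3. It involves different groups on a different core, and its size cannot be read, so it offers no size to carry over.

The estimate therefore rests mainly on compound 1 and is loose. The expected step is an at least 1.5-fold higher number from compound 1 to compound 4 (0.17 log units; that floor lies within the scatter), a modest one toward lower toxicity in this test, though its direction is far from certain. For compound 4 the estimated value is 15 ug/mL, with an expected range from 4 ug/mL to 80 ug/mL.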

Compound 4, half-maximal cytotoxic concentration: < 10 ug/mL
Compound 4 gave a limit, no number; the forecaster's own chance of this, stated with the estimate: 35%; at least 1.5-fold (0.17 log units) between middle value and limit.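

In this assay compound 4 gives < 10 ug/mL, which is a limit and not a number. Compound 1 also has only a limit, so no step can be read from compound 1 to compound 4. The compounds shown leave open whether chloro in place of isobutyl changes toxicity in this test at all, and by how much.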